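From compound 2 to compound 3: one group exchanged

The source may report more compounds than this note shows. Statements on the series, on what has been measured and on what is new or still open speak of the compounds shown alone.

Of the compounds shown here, two have numbers so far in an ADME assay on HEK293 cells (Homo sapiens) for cytotoxicity, read by MTT assay, with a stated time of 48 h; a lower number here means a stronger inhibitor, a higher number a weaker inhibitor. Compound 1 (`O=C1CS/C(=N/c2ccccc2)N1Cc1ccncc1`) gives 99500 nM. Compound 2 (`CC(C)c1ccc(/C=C2/S/C(=N/c3ccccc3)N(Cc3ccncc3)C2=O)cc1`) gives 137000 nM. These two values lie within the usual scatter of each other, so compound 2 does not stand apart from compound 1 in this assay.

Compound 3 (`O=C1/C(=C\c2cccc(Cl)c2)S/C(=N/c2ccccc2)N1Cc1ccncc1`) has not yet been measured. It carries 3-chlorophenyl in place of 4-isopropylphenyl on a double-bonded chain carbon bound to a double-bonded ring carbon.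

Among the compounds with values here, no measured pair differs in one place only, so no single exchange can serve as a guide. The expectation rests on the two values alone, with compound 1 at 99500 nM and compound 2 at 137000 nM. No step beyond the scatter is expected in this assay, and the estimated change is a 1.2-fold lower number from compound 2 to compound 3 (0.10 log units; within the scatter). For compound 3 the estimate is 110000 nM, with an expected range of 50000 nM to 220000 nM.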

Compound 3, half-maximal inhibitory concentration: 71800 nM
Estimate against measurement, compound 3: 1.5-fold (0.19 log units) above; low and high end bracket the measured number.
By their numbers in this assay, from the lowest: compounds 3, 1 and 2 (each within the scatter of the next).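

In this assay, within the data shown here, 3-chlorophenyl in place of 4-isopropylphenyl on a double-bonded chain carbon bound to a double-bonded ring carbon gives a 1.9-fold lower number from compound 2 to compound 3 (0.28 log units; within the scatter), the only single-place comparison so far. At this position, the two substituted phenyl groups therefore cannot be told apart in this read-out, even though they differ in substituent and in its place on the phenyl ring. No measured property of either group bears on this result, so the step carries no explanation.

This single exchange stays within the scatter and sets no trend, and it cannot separate the effect of swapping isopropyl for chlorine from the effect of moving the substituent on the phenyl ring; 4-chlorophenyl would separate the two. From the compounds shown here alone, whether the position stays equally indifferent to groups of another kind also remains open, for example a phenyl ring carrying an amine or a carboxylic acid, or a longer alkyl chain in place of the phenyl ring.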